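A few compounds are considered here, and "the series" means these few. Any claim that something is new, unique, unknown or untested is made for them only; others in the source may bear on it.

Measured compounds in a physicochemical assay for solubility, read by spectrophotometry, in phosphate buffer, with a stated time of 2 h, at pH 7.4; on this read-out higher numbers stand for higher solubility and lower numbers for lower solubility:
- compound 1 `COc1ccc2[nH]c(C(=O)N3CC(=O)N(Cc4ccccc4)[C@@H](COCc4ccccc4)C3)cc2c1` gives 8800 nM.
- compound 2 `COc1ccc2[nH]c(C(=O)N3CC(=O)N(Cc4ccccc4)[C@@H](CCN4CCC5(CC4)CC5)C3)cc2c1` gives > 25000 nM, which is a limit of this assay and not a number.
- compound 3 `COc1ccc2[nH]c(C(=O)N3CC(=O)N(Cc4ccccc4)[C@@H](N4[C@H](C)CCC[C@@H]4C)C3)cc2c1` gives 100000 nM.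

Compound 3 stands with the highest number among the values shown; the nearest read number belongs to compound 1, and the step of an 11-fold higher number from compound 1 to compound 3 (1.06 log units; beyond the scatter) is large. The step that the limit leaves unreadable from compound 2 to compound 3 cannot be sized because compound 2 sits at the limit of > 25000 nM in this assay, at which 1 of the 3 values shown sits.

Compound 4 `COc1ccc2[nH]c(C(=O)N3CC(=O)N(Cc4ccccc4)[C@@H](N4CCc5ccccc54)C3)cc2c1` differs from compound 3 by 2,3-dihydro-1H-indol-1-yl in place of 2,6-dimethylpiperidin-1-yl on a saturated ring carbon. The step of an 11-fold higher number from compound 1 to compound 3 (1.06 log units; beyond the scatter) bears on this change: there 2,6-dimethylpiperidin-1-yl took the place of a group carrying a six-membered aromatic ring of carbon only, and the number rose by a large step. The step of an at least 2.8-fold higher number from compound 1 to compound 2 (0.45 log units; beyond the scatter), also away from that aromatic group, went the same way. Compound 4 brings a six-membered aromatic ring of carbon only back in, here as part of 2,3-dihydro-1H-indol-1-yl. A downward step in this assay is therefore expected, of modest to large size, a 3.3-fold lower number from compound 3 to compound 4 (0.52 log units; beyond the scatter). Compound 4 is expected to give about 30000 nM, within 8000 nM to 100000 nM.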

Compound 4, solubility: 7000 nM
Estimate against measurement, compound 4: 4.3-fold (0.63 log units) above; the measured number lies below the stated range.
By their numbers in this assay, from the lowest: compounds 4 and 1 (each within the scatter of the next); then compound 3.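

In this assay, within the data shown here, at the saturated ring carbon next to the ring nitrogen, replacing 2,6-dimethylpiperidin-1-yl with 2,3-dihydro-1H-indol-1-yl gives a 14-fold lower number from compound 3 to compound 4 (1.15 log units; beyond the scatter), the first comparison of two groups attached at this carbon through a ring nitrogen. Compound 2 holds a limit of the assay and not a number, so an at least 3.5-fold lower number from compound 2 to compound 4 (0.55 log units; beyond the scatter) is a bound only: the limit of > 25000 nM in this assay, at which 1 of the 4 values shown sits. Replacing (benzyloxy)methyl with 2,3-dihydro-1H-indol-1-yl gives a 1.3-fold lower number from compound 1 to compound 4 (0.10 log units; within the scatter), so the two groups that carry a six-membered aromatic ring of carbon only show no readable difference, whether that ring is fused to the ring on the core-bound nitrogen or held on a chain.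

The compounds shown do not separate the aromatic ring from the other differences between these two groups, and a plain piperidin-1-yl, a pyrrolidin-1-yl or a 1,2,3,4-tetrahydroquinolin-1-yl at this carbon would bear on that. Also open, on these data alone, is how a carboxylic acid or an open-chain amine such as dimethylamino at this carbon would read in this assay.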